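This account rests on a few compounds, and the source may have more. Where it says the series, first, only, none or still open, it means among the compounds named here.

For the measured compounds named here, compound 3 `CC#C[C@@H](CC(=O)O)c1ccc(OC[C@H]2COc3ccc(C#N)cc3O2)cc1` gives 2100 nM in a functional assay on HEK293 cells for agonist activity at Free fatty acid receptor 1 (Homo sapiens), read by fluorescence and calcium flux, with a stated time of 10 min (a lower number here means that less compound is needed, a higher number that more compound is needed for the effect), the highest of the three numbers measured so far. Compound 1 `CC#C[C@@H](CC(=O)O)c1ccc(OC[C@H]2COc3ccccc3O2)cc1` gives 90 nM and compound 2 `CC#C[C@@H](CC(=O)O)c1ccc(OC[C@H]2COc3ccc(OC)cc3O2)cc1` gives 130 nM; the step of a 1.4-fold higher number from compound 1 to compound 2 (0.16 log units; within the scatter) lies within the scatter, whereas a 23-fold higher number from compound 1 to compound 3 (1.37 log units; beyond the scatter) and a 16-fold higher number from compound 2 to compound 3 (1.21 log units; beyond the scatter) are both large. Compound 4 `CC#C[C@@H](CC(=O)O)c1ccc(OC[C@H]2COc3ccc(C(=O)N(C)C)cc3O2)cc1` differs from compound 3 in one place: dimethylcarbamoyl in place of cyano on an aromatic carbon. Going by the values given here, the two large steps into compound 3 bear on this change, since both remove hydrogen or methoxy in favour of cyano, but no measured step shows what dimethylcarbamoyl does in this assay. For compound 4 the expected step is therefore a 4.2-fold lower number from compound 3 to compound 4 (0.62 log units; beyond the scatter), a partial return and uncertain in size. Compound 4 is expected to give about 500 nM, between 100 nM and 2500 nM.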

Compound 4, half-maximal effective concentration: > 30000 nM
Compound 4 gave a limit, no number; the forecaster's own chance of this, stated with the estimate: 5%; at least 60-fold (1.77 log units) between middle value and limit.
By their numbers in this assay, from the lowest: compounds 1 and 2 (each within the scatter of the next); then compound 3. At a limit, above all of these: compound 4.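

In this assay compound 4 reaches a limit of the assay, not a number: the limit of > 30000 nM in this assay, at which 1 of the 4 values shown sits. At this aromatic carbon, dimethylcarbamoyl goes well beyond the loss seen with cyano, with an at least 14-fold higher number from compound 3 to compound 4 (1.15 log units; beyond the scatter). The gaps to methoxy and hydrogen are wider still, with an at least 230-fold higher number from compound 2 to compound 4 (2.36 log units; beyond the scatter) and an at least 330-fold higher number from compound 1 to compound 4 (2.52 log units; beyond the scatter), so the tolerance shown by compound 2 does not extend to every group here.

The compounds shown leave open where a primary carboxamide, an amine or a carboxylic acid at this carbon would fall. As far as these compounds go, the true value of compound 4 also remains unknown.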